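A few compounds are considered here, and "the series" means these few. Any claim that something is new, unique, unknown or untested is made for them only; others in the source may bear on it.

In a functional assay on HepG2 cells (Homo sapiens) for inhibition, with a stated time of 72 h (a lower number here means a stronger inhibitor, a higher number a weaker inhibitor), compound 1 `O=C(Nc1ccccc1)Nc1nc(Sc2c[nH]c3ccccc23)cc(N2CCCC2)n1` gives 11400 nM while compound 2 `COc1ccc(NC(=O)Nc2nc(Sc3c[nH]c4ccccc34)cc(N3CCCC3)n2)cc1` gives 20300 nM and compound 3 `Cc1cc(Cl)ccc1NC(=O)Nc1nc(Sc2c[nH]c3ccccc23)cc(N2CCCC2)n1` gives 7150 nM on the same core. Compound 1 sits within the scatter of both others, as a 1.8-fold higher number from compound 1 to compound 2 (0.25 log units; within the scatter) and a 1.6-fold lower number from compound 1 to compound 3 (0.20 log units; within the scatter) show, so it cannot be ranked against either of them. Only the third step between these compounds passes the scatter, and it is modest.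

Compound 4 `O=C(Nc1ccccc1)Nc1nc(Sc2c[nH]c3ccccc23)cc(N2CCCCC2)n1` differs from compound 1 in one group, with piperidin-1-yl in place of pyrrolidin-1-yl on an aromatic carbon. Going by the values given here, no measured compound changes that group, so the data hold no direct evidence for this swap. All three measured steps alter the aromatic group on the amide-type nitrogen instead, and they serve only as a rough yardstick of size. The largest of them, a 2.8-fold lower number from compound 2 to compound 3 (0.45 log units; beyond the scatter) and involving compound 3, is modest, so no step beyond the scatter is expected in this assay and no direction can be argued. The expected change is small, namely a 1.1-fold lower number from compound 1 to compound 4 (0.06 log units; within the scatter) as an estimate within the scatter. For compound 4 the expected value is 10000 nM with an estimated range of 4500 nM to 22000 nM around it.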

Compound 4, half-maximal inhibitory concentration: 20900 nM
For compound 4 the middle estimate is 2.1-fold (0.32 log units) below the measured one; low and high end bracket the measured number.
By their numbers in this assay, from the lowest: compounds 3, 1, 2 and 4 (each within the scatter of the next, the first and the last beyond it).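

In this assay, piperidin-1-yl in place of pyrrolidin-1-yl, on an aromatic carbon next to the ring nitrogen, gives a 1.8-fold higher number from compound 1 to compound 4 (0.26 log units; within the scatter) and so leaves compound 1 and compound 4 indistinguishable. Going by these compounds alone, the earlier compounds differed only in the aromatic group on the amide-type nitrogen, so this step is the only direct reading at this position, and it shows that a six-membered non-aromatic ring can stand where the five-membered one stood without a step beyond the scatter. No measurement of any property of these two groups is available to account for the result.

From the compounds shown here alone, it remains open whether a different kind of group at this position, such as morpholin-4-yl with its added ring oxygen, an open-chain dimethylamino group or a simple hydrogen, would give a step beyond the scatter in either direction. Within the data shown here, it is also open whether piperidin-1-yl would behave the same way alongside the 4-chloro-2-methylphenyl group on the amide-type nitrogen, since the one step at this position was read with phenyl on that nitrogen.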